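A Single Fluorine Removed from a Thiazole Hydrazone Pair

This account rests on a few compounds, and the source may have more. Where it says the series, first, only, none or still open, it means among the compounds named here.

Two compounds share a core in which a thiazole-bearing hydrazone links two aromatic rings. Compound 1 `Clc1ccc(-c2csc(N/N=C/c3cccs3)n2)cc1` carries a thiophene on the hydrazone side, and in a functional assay, read by spectrophotometry, with a stated time of 15 min, tested at 60 ug/mL (a lower number here means a weaker effect, a higher number a stronger effect of the compound at the concentration tested), compound 1 gives 96.1%. Compound 2 `Fc1ccc(-c2csc(N/N=C/c3ccc(Cl)cc3Cl)n2)cc1` carries instead a dichlorophenyl on that side and a fluoro on the other ring; in this assay compound 2 gives 94.6%. Compound 2 therefore stands within the scatter of compound 1, and the two numbers cannot be told apart.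

Compound 3 `Clc1ccc(/C=N/Nc2nc(-c3ccccc3)cs2)c(Cl)c1` differs from compound 2 in one place: hydrogen in place of fluoro on an aromatic carbon, so that the 4-fluorophenyl of compound 2 becomes a plain phenyl in compound 3. Among the measured compounds shown here, no measured pair in this set shows what that kind of change does.

With both measured numbers near the top of the scale and the change a small one, the step from compound 2 to compound 3 is expected to be a number 2.6 percentage points lower from compound 2 to compound 3 (within the scatter), which is not beyond the scatter. Compound 3 is therefore estimated to give 92% in this assay, in the range 80% to 98%.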

Compound 3, a percentage reported as inhibition, at one concentration (the size of the read-out at that concentration, not a potency): 92.8%
Estimate against measurement, compound 3: 0.8 percentage points below; the measured number falls inside the stated range.
By their numbers in this assay, from the lowest: compounds 3, 2 and 1 (each within the scatter of the next).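

Among the compounds shown here, removing the fluoro from the 4-fluorophenyl of compound 2 gives the first comparison in this set that changes one place alone, and in this assay the change reads as a number 1.8 percentage points lower from compound 2 to compound 3 (within the scatter) and so cannot be told apart from repeated measurement. At this position, on an aromatic carbon of the six-membered ring and para to a large group, the fluoro is therefore not needed to keep the read-out at the level seen for compound 2, at this one concentration. No measured finding is available to explain this result.

What the compounds shown leave open is how far this tolerance extends, since this single step compares only fluoro with hydrogen, and compound 1 differs from compound 2 and compound 3 in more than one place, so it gives no separate reading of the position. An amine, a carboxylic acid or a longer chain on the same carbon remains untested in the compounds shown, and a read-out at one concentration, close to the top of the scale, cannot say whether potency differs between compound 2 and compound 3.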